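Swapping the aryl group on compound 2 for a pyridinone-like ring

The source may report more compounds than this note shows. Statements on the series, on what has been measured and on what is new or still open speak of the compounds shown alone.

Of the compounds shown here, three have been measured in a physicochemical assay for solubility, in phosphate buffer, at pH 7.4; a lower number here means a less soluble compound, a higher number a more soluble compound. Compound 1 `CC(C)n1nc(-c2ccnc3[nH]c(C4CCN(CC(=O)N(C)C)CC4)cc23)ccc1=O` gives 11000 nM. Compound 2 `COc1cc(F)ccc1-c1ccnc2[nH]c(C3CCN(CC(=O)N(C)C)CC3)cc12` gives 38000 nM, and compound 3 `COc1cc(F)ccc1-c1ccnc2[nH]c(C3CCN(C(C)=O)CC3)cc12` gives 50000 nM. Among these three numbers compound 2 stands second highest; its nearest neighbour is compound 3, from which it is separated by a 1.3-fold higher number from compound 2 to compound 3 (0.12 log units; within the scatter), while compound 1 lies furthest from it, with a 3.5-fold higher number from compound 1 to compound 2 (0.54 log units; beyond the scatter).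

Compound 4 `COc1cc(=O)n(C)cc1-c1ccnc2[nH]c(C3CCN(CC(=O)N(C)C)CC3)cc12` has not yet been measured. It differs from compound 2 in one place: a group of 10 heavy atoms (7 carbon, 1 nitrogen, 2 oxygen; one six-membered aromatic ring with 1 hetero atom) in place of a group of 9 heavy atoms (7 carbon, 1 oxygen, 1 fluorine; one six-membered aromatic ring of carbon only), on an aromatic carbon

Going by the values given here, the only measured step that bears on this change is the one at the same position, from compound 1 to compound 2, where a group with one six-membered aromatic ring with 2 hetero atoms was replaced by the 4-fluoro-2-methoxyphenyl group and the number rose by a 3.5-fold higher number from compound 1 to compound 2 (0.54 log units; beyond the scatter). Compound 4 reverses that kind of exchange, putting a six-membered aromatic ring with 1 hetero atom and 3 hydrogen-bond acceptors back in place of the carbon-only ring. Compound 4 is therefore expected to move back toward compound 1, by an estimated 2.5-fold lower number from compound 2 to compound 4 (0.40 log units; beyond the scatter) in this assay. For compound 4 the estimate in this assay is 15000 nM, within a range from 6000 nM to 40000 nM.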

Compound 4, solubility: 670000 nM
Compound 4: middle estimate off by 45-fold (1.65 log units), on the low side; measured number above the stated range.
By their numbers in this assay, from the lowest: compound 1; then compounds 2 and 3 (each within the scatter of the next); then compound 4.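

In this assay, going by these compounds alone, the position on the aromatic carbon opposite the ring nitrogen proves far more responsive than the earlier compounds showed. Within the data shown here, the exchange of 4-fluoro-2-methoxyphenyl for the new ring gives an 18-fold higher number from compound 2 to compound 4 (1.25 log units; beyond the scatter), a larger move in the opposite direction from what a ring with hetero atoms had suggested when the only earlier step at this position was a 3.5-fold higher number from compound 1 to compound 2 (0.54 log units; beyond the scatter). The two rings with hetero atoms also part widely, with a 61-fold higher number from compound 1 to compound 4 (1.78 log units; beyond the scatter), so among compound 1, compound 2 and compound 4 the order does not follow the number of hetero atoms in the ring: the carbon-only ring of compound 2 stands between the ring with 2 hetero atoms and the ring with 1.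

Still open, going by these compounds, is which part of the entering group carries this step, whether a ring bearing an amine or a carboxylic acid at this position would fall nearer compound 4 or compound 1, and whether the step would hold with the acetyl group of compound 3 on the ring nitrogen of the piperidine-bearing side. No experimental information is available to account for the size or direction of these differences.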